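Moving one methyl group on compound 2

This account rests on a few compounds, and the source may have more. Where it says the series, first, only, none or still open, it means among the compounds named here.

In a functional assay on MCF7 cells (Homo sapiens) for inhibition, read by MTT assay, with a stated time of 24 h (on this read-out higher numbers stand for weaker inhibition and lower numbers for stronger inhibition), compound 2 `Cc1ccc(OCc2nnc(S)n2N2C(=O)CSC2c2c[nH]nc2-c2ccc(F)cc2)cc1` gives > 100 ug/mL, which is a limit of the assay and not a number. Compound 1 `O=C1CSC(c2c[nH]nc2-c2ccc(Cl)cc2)N1n1c(S)nnc1COc1cccc2ccccc12` gives 100 ug/mL, and compound 3 `COc1ccc(-c2n[nH]cc2C2SCC(=O)N2n2c(S)nnc2COc2ccc(C)cc2)cc1` gives 78 ug/mL. Compound 4 `Cc1ccccc1OCc1nnc(S)n1N1C(=O)CSC1c1c[nH]nc1-c1ccc(F)cc1` has the same atoms as compound 2, joined differently: 2-methylphenyl in place of 4-methylphenyl on an oxygen on a saturated carbon. It carries 2-methylphenyl in place of 4-methylphenyl on an oxygen on a saturated carbon. Among the compounds with values here, no measured step makes this exact change. Within the data shown here, the one step that bears on it, an at least 1.2-fold lower number from compound 2 to compound 3 (0.10 log units; that floor lies within the scatter), concerns a different group, and its floor lies within the scatter. On that evidence, no change beyond the scatter is expected in this assay, and the expected step is a number no higher from compound 2 to compound 4 (the limit leaves the size open). Compound 4 is estimated at 100 ug/mL, with an expected range of 60 ug/mL to 170 ug/mL.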

Compound 4, half-maximal inhibitory concentration: > 100 ug/mL
Compound 4: a limit, no number (the forecaster's own chance of this, stated with the estimate: 50%); the middle value lies on the limit itself.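

In this assay, within the data shown here, compound 2 and compound 4 each give a limit and not a number, and no step between them can be read. The compounds shown leave open whether 2-methylphenyl in place of 4-methylphenyl changes inhibition at all.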